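The source may hold more compounds than are shown below. What is called first, only, known or untested is meant among the compounds shown, and "the series" means these compounds.

Measured compounds in a functional assay on HOS-TE85 cells (Homo sapiens) for inhibition, read by CCK-8 assay, with a stated time of 72 h, tested at 1 uM; on this read-out lower numbers stand for less inhibition and higher numbers for more inhibition at the one concentration tested (going by the name of the read-out):
Compound 1 `COc1ccc(OC)c(N2C(=O)CSC2c2cccc(C(=O)NCCCCc3ccccc3)c2)c1`: 20%
Compound 2 `O=C(NCCCCc1ccccc1)c1cccc(C2SCC(=O)N2c2ccccc2F)c1`: 95%

Compound 2 stands highest of the two numbers in this assay; its nearest neighbour is compound 1, whose value is lower by a step beyond the scatter. Going by the values given here, that one measured step, a number 75 percentage points higher from compound 1 to compound 2 (beyond the scatter), shows how strongly the group on the amide-type nitrogen in the ring governs the read-out, and it is the only step that bears on the change now considered.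

Compound 3 `CC(F)(F)c1cccc(N2C(=O)CSC2c2cccc(C(=O)NCCCCc3ccccc3)c2)c1` differs from compound 2 as follows: a group of 10 heavy atoms (8 carbon, 2 fluorine; one six-membered aromatic ring of carbon only) in place of a group of 7 heavy atoms (6 carbon, 1 fluorine; one six-membered aromatic ring of carbon only), on an amide-type nitrogen in a ring. The group on the ring nitrogen changes again, but this time from one fluorinated aromatic ring to another, so the direction cannot be taken from the single step shown. Given that the site is sensitive, a step of moderate size is expected, most likely downward from the high value of compound 2, as a number 30 percentage points lower from compound 2 to compound 3 (beyond the scatter). Compound 3 is therefore estimated at 65%, within a range of 20% to 95%.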

Compound 3, a percentage reported as inhibition, at one concentration (the size of the read-out at that concentration, not a potency): 93%
The estimate for compound 3 lay 28 percentage points below the measured number; low and high end bracket the measured number.
By their numbers in this assay, from the lowest: compound 1; then compounds 3 and 2 (each within the scatter of the next).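

In this assay, placing a group of 10 heavy atoms (8 carbon, 2 fluorine) on the amide-type nitrogen in place of 2-fluorophenyl gives a number 2 percentage points lower from compound 2 to compound 3 (within the scatter), so this position accepts either group without a change beyond the scatter. The 2,5-dimethoxyphenyl group also has 10 heavy atoms, yet replacing it with the group of compound 3 gives a number 73 percentage points higher from compound 1 to compound 3 (beyond the scatter), so among these three compounds the heavy-atom count does not follow the read-out. No measurement at hand gives a reason for either step.

From the compounds shown here alone, whether a carboxylic acid, an amine or a cyclohexyl group on the amide-type nitrogen would hold the number stays open. Readings at one concentration also leave open whether compound 2 and compound 3 would separate at lower concentrations.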